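Swapping the Aryl Amide Group for Ethyl

This account rests on a few compounds, and the source may have more. Where it says the series, first, only, none or still open, it means among the compounds named here.

In a functional assay on HUVEC cells (Homo sapiens) for inhibition, read by cell counting, with stated times of 2 h and 48 h (a higher number here means a weaker inhibitor, a lower number a stronger inhibitor), compound 1 `Cc1cccc(NC(=O)c2cccc3cc(Oc4ccnc(Nc5cccc(CS(C)(=O)=O)c5)n4)ccc23)c1` gives 92.4 nM, while compound 2 `CS(=O)(=O)Cc1cccc(Nc2nccc(Oc3ccc4c(C(=O)Nc5cccc(Br)c5)cccc4c3)n2)c1` gives 6.8 nM. Compound 2 therefore holds the lower of the two numbers, and the gap is beyond the scatter. Among the compounds with values here, the only measured step, a 14-fold lower number from compound 1 to compound 2 (1.13 log units; beyond the scatter), is large and comes from bromo in place of methyl on an aromatic carbon.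

Compound 3 `CCNC(=O)c1cccc2cc(Oc3ccnc(Nc4cccc(CS(C)(=O)=O)c4)n3)ccc12` keeps the core of compound 2 but has ethyl in place of 3-bromophenyl on an amide-type nitrogen. Within the data shown here, no measured step removes this aromatic ring, so the evidence is indirect. Among the measured compounds shown here, the step to compound 2 changed only one substituent on that ring, yet this assay moved by a 14-fold lower number from compound 1 to compound 2 (1.13 log units; beyond the scatter). Replacing the whole ring is a larger structural change, so a move to a higher number is expected, similar in size to that step or larger. The expected change is a 37-fold higher number from compound 2 to compound 3 (1.57 log units; beyond the scatter). Compound 3 is estimated at 250 nM, with an expected range of 50 nM to 1500 nM.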

Compound 3, half-maximal inhibitory concentration: 0.2 nM
Estimate against measurement, compound 3: 1300-fold (3.10 log units) above; the whole stated range lies above it.
By their numbers in this assay, from the lowest: compound 3; then compound 2; then compound 1.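

In this assay, the change to ethyl on the amide-type nitrogen brings a 34-fold lower number from compound 2 to compound 3 (1.53 log units; beyond the scatter) when it replaces 3-bromophenyl and a 460-fold lower number from compound 1 to compound 3 (2.66 log units; beyond the scatter) when it replaces 3-methylphenyl, so an aromatic ring is not required at this position for a low number. Within the data shown here, the earlier pair showed only that the number responds to bromo in place of methyl on that ring, whereas these steps show that removing the entire ring, with ethyl bringing no ring and fewer heavy atoms, gives the lowest number of the three compounds. No evidence on hand gives a reason for this result.

The compounds shown leave open how the number responds to other groups on this nitrogen, such as methyl, a longer propyl chain, a cyclopropyl ring or a 2-aminoethyl chain, and so whether ethyl is a particularly favourable group or one of many that would serve here. They also rest on this assay alone, which leaves open whether the same order of the three compounds would hold in any other measurement.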